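The compounds below may be only part of what the source reports. "The series", "measured", "known", "first", "only" and "open" are said of these compounds alone.

Working notes on the series. The shared core carries an aromatic ring bearing chloro and methoxy groups, as in compound 1 `COc1ccc(S(=O)(=O)NCCN2CCC(CCC(=O)c3cc(Cl)c(N)cc3OC)CC2)cc1Cl`, which in an assay on HEK293 cells for displacement of a labelled ligand from 5-hydroxytryptamine receptor 6 (Homo sapiens), with a stated time of 60 min, tested at 0.01 uM, in the presence of a further agent that is not named here (on this read-out higher numbers stand for a stronger effect at the one concentration tested and lower numbers for a weaker effect), gives 20%. Compound 2 `COc1ccc(S(=O)(=O)NCCN2CCC(CCC(=O)c3cc(Cl)c(N)cc3OC)CC2)cc1OC` differs by methoxy in place of chloro on an aromatic carbon and gives 3%; the step of a number 17 percentage points lower from compound 1 to compound 2 (beyond the scatter). Among the measured compounds shown here, compound 2 thus stands lowest of the two numbers measured so far, with compound 1 the only neighbour, beyond the scatter above it.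

Compound 3 `COc1cc(N)c(Cl)cc1C(=O)CCC1CCN(CCNS(=O)(=O)c2ccc(OC)c(N3CCN(C)CC3)c2)CC1` is not yet measured. It differs from compound 2 by 4-methylpiperazin-1-yl in place of methoxy on an aromatic carbon, the change sitting on an aromatic carbon of a six-membered aromatic ring of carbon only, ortho to a methoxy group. For the measured compounds named here, the one measured step, from compound 1 to compound 2, concerns a different exchange on that ring and does not bear directly on 4-methylpiperazin-1-yl in place of methoxy; no measured step addresses this change. With compound 2 already near the floor of the read-out, little room remains downward, and the expected step of a number 12 percentage points higher from compound 2 to compound 3 (beyond the scatter) is small, perhaps upward, with wide uncertainty. Compound 3 is estimated at 15%, in the range 0% to 45%.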

Compound 3, a percentage reported as inhibition, at one concentration (the size of the read-out at that concentration, not a potency): 4%
For compound 3 the middle estimate is 11 percentage points above the measured one; measured number inside the range.
By their numbers in this assay, from the lowest: compounds 2 and 3 (each within the scatter of the next); then compound 1.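

In this assay, at this position on an aromatic carbon, ortho to a methoxy group, the step to 4-methylpiperazin-1-yl with its 7 heavy atoms and one six-membered non-aromatic ring is a number 1 percentage points higher from compound 2 to compound 3 (within the scatter); at the one concentration tested, this read-out does not separate that group from methoxy, with its 2 heavy atoms. Against chloro, the piperazine gives a number 16 percentage points lower from compound 1 to compound 3 (beyond the scatter), of much the same size as a number 17 percentage points lower from compound 1 to compound 2 (beyond the scatter), so among the three groups shown at this position, only chloro stands apart from the other two, and compound 1 is the only compound beyond the scatter of the rest. No measurement shown here accounts for these numbers.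

Going by these compounds, whether bromo or fluoro at this position would stay level with compound 1 or fall to the level of compound 2 and compound 3 remains open, as does the result for a small amine such as dimethylamino. Also open, on these data alone, is whether methoxy and 4-methylpiperazin-1-yl would separate at a higher concentration, where the read-out would lie further from its floor.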